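Trifluoromethyl for fluoro beside a chloro-bearing ring

The compounds below may be only part of what the source reports. "The series", "measured", "known", "first", "only" and "open" are said of these compounds alone.

Measured so far in a functional assay on A549 cells (Homo sapiens) for cytotoxicity, read by MTT assay, with a stated time of 72 h; a higher number here means a weaker inhibitor, a lower number a stronger inhibitor:
- compound 1, `Cn1ccc2c(Oc3ccc(NC(=O)c4nn(-c5ccc(Cl)c(F)c5)ccc4=O)cc3)ccnc21`: compound 1 gives > 60000 nM, a limit of the assay.
- compound 2, `Cn1ccc2c(Oc3ccc(NC(=O)c4nn(-c5ccc(Cl)c(C(F)(F)F)c5)ccc4=O)cc3)ccnc21`: compound 2 gives 11400 nM.
- compound 3, `Cn1ccc2c(Oc3ccc(NC(=O)c4nn(-c5ccc(Cl)c(F)c5)ccc4=O)cc3F)ccnc21`: compound 3 gives > 60000 nM, a limit of the assay.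

Compound 2 differs from compound 1 by trifluoromethyl in place of fluoro on an aromatic carbon, and that change gave an at least 5.2-fold lower number from compound 1 to compound 2 (0.72 log units; beyond the scatter). Compound 3 differs from compound 1 by fluoro in place of hydrogen on an aromatic carbon; here the data give a step that the two limits leave unreadable from compound 1 to compound 3, so how the added fluoro acts is not readable. For the measured compounds named here, two of the three values sit at the limit of > 60000 nM in this assay, at which 2 of the 3 values shown sit, which leaves only one real number among them.

Compound 4, `Cn1ccc2c(Oc3ccc(NC(=O)c4nn(-c5ccc(Cl)c(C(F)(F)F)c5)ccc4=O)cc3F)ccnc21`, is not yet measured. Going by the values given here, it differs from compound 3 by trifluoromethyl in place of fluoro on an aromatic carbon, the same change as the one from compound 1 to compound 2, and at the same place. The expectation for compound 4 rests on that earlier step: from compound 3 the estimated step is an at least 4.0-fold lower number from compound 3 to compound 4 (0.60 log units; beyond the scatter). Compound 4 is therefore expected to give about 15000 nM in this assay, plausibly between 5000 nM and 60000 nM, with a real chance that only a limit is reported.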

Compound 4, half-maximal inhibitory concentration: 17700 nM
The estimate for compound 4 lay 1.2-fold (0.07 log units) below the measured number; the range from low to high includes it.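

In this assay, trifluoromethyl in place of fluoro lowered the number again on the core of compound 3, with an at least 3.3-fold lower number from compound 3 to compound 4 (0.53 log units; beyond the scatter), so in the two pairs shown the change carries from one core to the other. This does not show that the gain is the same size on both cores: the same change on two cores in this assay, an at least 5.2-fold lower number (0.72 log units; beyond the scatter) from compound 1 to compound 2 and an at least 3.3-fold lower number (0.53 log units; beyond the scatter) from compound 3 to compound 4; the limit leaves it open whether they differ. The added fluoro can be read only between the two compounds that carry trifluoromethyl, with a 1.6-fold higher number from compound 2 to compound 4 (0.19 log units; within the scatter), because the other pair gives no usable number: the limit of > 60000 nM in this assay, at which 2 of the 4 values shown sit.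

The compounds shown leave open whether a different group at that place, such as a methyl, a nitrile or an amine, would match trifluoromethyl. They also leave open whether the change would carry to cores beyond these two, or to cells other than those tested here.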